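A few compounds are considered here, and "the series" means these few. Any claim that something is new, unique, unknown or untested is made for them only; others in the source may bear on it.

Compound 3 `O=C(COc1ccc2c(=O)ccoc2c1)Nc1cccc(NC(=O)c2cccc([N+](=O)[O-])c2)c1` stands with the highest number of the three compounds measured in an assay on isolated protein for inhibition of Rho-associated protein kinase 1 (Homo sapiens), read by scintillation counting, radiometric assay and 33P incorporation, with a stated time of 40 min, in the presence of a further agent that is not named here; on this read-out lower numbers stand for stronger inhibition and higher numbers for weaker inhibition: compound 3 gives 528 nM, while compound 1 `CCCc1ccc(C(=O)Nc2cccc(NC(=O)COc3ccc4c(=O)ccoc4c3)c2)cc1` gives 143 nM and compound 2 `CCOc1ccc(C(=O)Nc2cccc(NC(=O)COc3ccc4c(=O)ccoc4c3)c2)cc1` gives 17 nM. The steps to it are a 3.7-fold higher number from compound 1 to compound 3 (0.57 log units; beyond the scatter) and a 31-fold higher number from compound 2 to compound 3 (1.49 log units; beyond the scatter), both beyond the scatter; within the shared core, the step of an 8.4-fold lower number from compound 1 to compound 2 (0.92 log units; beyond the scatter) shows how much one substituent change can move the read-out.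

Compound 4 `O=C(COc1ccc2c(=O)ccoc2c1)Nc1cccc(NC(=O)c2ccc(C(=O)O)cc2)c1` is not yet measured. The change from compound 3 is 4-carboxyphenyl in place of 3-nitrophenyl on a carbonyl carbon. Within the data shown here, no measured pair shows a 4-carboxyphenyl group, so no step speaks to it directly; the two steps that end at compound 3 only show that replacing 3-nitrophenyl with either of the other groups gave a lower number. On that basis a lower number than compound 3 is expected for compound 4, with a broad range, roughly a 1.8-fold lower number from compound 3 to compound 4 (0.25 log units; within the scatter). The estimate for compound 4 in this assay is 300 nM, between 60 nM and 1500 nM.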

Compound 4, half-maximal inhibitory concentration: 6890 nM
Compound 4: the middle estimate sits 23-fold (1.36 log units) below what was measured; measured number above the stated range.
By their numbers in this assay, from the lowest: compound 2; then compound 1; then compound 3; then compound 4.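

The earlier compounds shown here had put 3-nitrophenyl at the high end on this carbonyl carbon, but 4-carboxyphenyl goes further, with a 13-fold higher number from compound 3 to compound 4 (1.12 log units; beyond the scatter), which makes compound 4 the weakest inhibitor of the four. On the aromatic carbon that carries the substituent, carboxy falls far behind both groups it can be compared with directly, with a 410-fold higher number from compound 2 to compound 4 (2.61 log units; beyond the scatter) for ethoxy and a 48-fold higher number from compound 1 to compound 4 (1.68 log units; beyond the scatter) for propyl, so the span at this one place is much wider than the earlier steps had shown. The data offer no explanation for the size of these steps.

The compounds shown leave open whether a methyl ester or a primary amide in place of the carboxylic acid would give a number closer to those of the ethoxy and propyl compounds. They also leave open how an amine on the same aromatic carbon would read out.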